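A Phenyl Anilide Replaces a Protected Amine Chain

The source may hold more compounds than are shown below. What is called first, only, known or untested is meant among the compounds shown, and "the series" means these compounds.

Three compounds have numbers in a functional assay on PC-3 cells (Homo sapiens) for antiproliferative activity, read by MTT assay, with a stated time of 72 h; a lower number here means a stronger inhibitor, a higher number a weaker inhibitor:
compound 1 `CCCSc1nc(Cl)c2c(n1)N(Cc1ccccc1)C(C(=O)N1CCN(C(=O)OC(C)(C)C)CC1)N2` gives 47100 nM;
compound 2 `CCCSc1nc(Cl)c2c(n1)N(Cc1cccs1)C(C(=O)N1CCN(C)CC1)N2` gives 5020 nM;
compound 3 `CCCSc1nc(Cl)c2c(n1)N(Cc1ccccc1)C(C(=O)NCCNC(=O)OC(C)(C)C)N2` gives 29700 nM.

Compound 3 sits at the high end together with compound 1, the two lying within the scatter of each other, so they cannot be told apart. Compound 2 sits clearly lower, beyond the scatter. Compound 4 `CCCSc1nc(Cl)c2c(n1)N(Cc1ccccc1)C(C(=O)Nc1ccccc1)N2` keeps everything of compound 3 except the amide side, where the change is phenyl in place of 2-((tert-butoxycarbonyl)amino)ethyl on an amide-type nitrogen. Within the data shown here, no pair of measured compounds shows this change alone, so its size is unknown from the data. A moderate step is expected, probably toward a lower number, though it may not clear the scatter. The step from compound 3 to compound 4 is estimated as a 1.5-fold lower number from compound 3 to compound 4 (0.17 log units; within the scatter). Compound 4 is expected to give about 20000 nM, between 5000 nM and 70000 nM.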

Compound 4, half-maximal inhibitory concentration: > 64000 nM
Compound 4: only a limit was reported (the forecaster's own chance of this, stated with the estimate: 5%); middle value at least 3.2-fold (0.50 log units) away from the limit.
By their numbers in this assay, from the lowest: compound 2; then compounds 3 and 1 (each within the scatter of the next). At a limit, above all of these: compound 4.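

In this assay, putting phenyl in place of 2-((tert-butoxycarbonyl)amino)ethyl on the amide-type nitrogen gives an at least 2.1-fold higher number from compound 3 to compound 4 (0.33 log units; beyond the scatter). Among these compounds, this shows that the group at this position matters and that this aromatic ring brings no gain here, a single-change comparison the earlier compounds did not offer. The step gives only a minimum size, since compound 4 returned a limit rather than a number: the limit of > 64000 nM in this assay, at which 1 of the 4 values shown sits.

As far as these compounds go, how far compound 4 lies past that limit remains unknown. Also open, from the compounds shown here alone, is whether a chain ending in a free amine or a carboxylic acid would give a lower number on this nitrogen.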